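The source may hold more compounds than are shown below. What is called first, only, known or untested is meant among the compounds shown, and "the series" means these compounds.

Measured so far:

Compound 1 `Clc1ccccc1-c1n[nH]cc1N1CCNCC1` — > 10000 nM
Compound 2 `Clc1cccc(-c2n[nH]cc2N2CCNCC2)c1` — > 10000 nM
Compound 3 `Fc1ccccc1-c1n[nH]cc1N1CCNCC1` — > 10000 nM

Of the compounds shown here, three built on a shared core have been tested in an assay on isolated protein for binding affinity to 5-hydroxytryptamine receptor 4 (Homo sapiens); a higher number here means a weaker inhibitor, a lower number a stronger inhibitor. Compound 1 `Clc1ccccc1-c1n[nH]cc1N1CCNCC1` gives only a limit there, > 10000 nM. Compound 3 `Fc1ccccc1-c1n[nH]cc1N1CCNCC1` likewise gives only a limit in this assay, > 10000 nM. Compound 2 `Clc1cccc(-c2n[nH]cc2N2CCNCC2)c1` gives only a limit as well, > 10000 nM. How the core of compound 2 differs from that of compound 1 is not broken down here.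

From compound 1 to compound 3 the change is fluoro in place of chloro on an aromatic carbon, and the step in this assay is a step that the two limits leave unreadable from compound 1 to compound 3; the two values leave the size unreadable because of the limit of > 10000 nM in this assay, at which 3 of the 3 values shown sit.

Compound 4 `Fc1cccc(-c2n[nH]cc2N2CCNCC2)c1` is not yet measured. It stands to compound 2 as compound 3 stands to compound 1: the change is fluoro in place of chloro on an aromatic carbon. The place is not the same in words, since in compound 1 the chloro sits ortho to a large group and in compound 2 meta to a large group, so this is the same kind of change rather than the same change. Since every value shown sits at the limit, the step from compound 2 to compound 4 in this assay is expected to be a step that the limit leaves unreadable from compound 2 to compound 4. Compound 4 is expected to give 20000 nM in this assay, most likely again only a limit, with an estimated range from 5000 nM to 100000 nM.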

Compound 4, inhibition constant: > 10000 nM
Compound 4 was reported as a limit; the forecaster's own chance of this, stated with the estimate: 85%; the middle value lies beyond the limit too.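

Compound 4 gives > 10000 nM in this assay, and this value is a limit, not a number. No size can be read for the step between compound 2 and compound 4, with fluoro in place of chloro, because neither compound has a value beyond a limit: the limit of > 10000 nM in this assay, at which 4 of the 4 values shown sit.

The compounds shown leave open what affinity any of the four has, and whether that change alters it.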